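Triazole-linked tetracyclic series: cytotoxicity in MCF7 cells

This account rests on a few compounds, and the source may have more. Where it says the series, first, only, none or still open, it means among the compounds named here.

Measured compounds:
- Compound 1 `C=C1C[C@]23C[C@@]1(O)CC[C@@H]2c1cccc(C)c1[C@@H]3Cn1cc(-c2ccc(OC)cc2)nn1`. In a functional assay on MCF7 cells (Homo sapiens) for cytotoxicity, read by MTT assay, with a stated time of 4 days (on this read-out lower numbers stand for stronger inhibition and higher numbers for weaker inhibition), compound 1 gives > 20000 nM, which is a limit of the assay, not a number.
- Compound 3 `C=C1C[C@]23C[C@@]1(O)CC[C@@H]2c1cccc(C)c1[C@@H]3Cn1cc(-c2ccc(C)cc2)nn1`. In this assay compound 3 gives > 20000 nM, also a limit.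
- Compound 2 `Cc1ccc(-c2cn(C[C@H]3c4c(ccc(O)c4C)[C@@H]4CC[C@@]5(C)C[C@]43CC5=O)nn2)cc1`. In this assay compound 2 gives > 20000 nM, also a limit.

Compounds 1 and 3 share one core and differ by methoxy in place of methyl on an aromatic carbon. The step that the two limits leave unreadable from compound 3 to compound 1 has no readable size, because both values sit at the limit of > 20000 nM in this assay, at which 3 of the 3 values shown sit. Compound 2 carries another core; the difference between the cores of compound 2 and compound 3 is not broken down here.

Compound 4 `COc1ccc(-c2cn(C[C@H]3c4c(ccc(O)c4C)[C@@H]4CC[C@@]5(C)C[C@]43CC5=O)nn2)cc1` is not yet measured. It arises from compound 2 by methoxy in place of methyl on an aromatic carbon, the same change as from compound 3 to compound 1. The expected step is a step that the limit leaves unreadable from compound 2 to compound 4, resting on compound 2 sitting at the limit of > 20000 nM in this assay, at which 3 of the 3 values shown sit, in this assay. Compound 4 is expected near 30000 nM, between 10000 nM and 100000 nM, most likely again reported only as a limit.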

Compound 4, half-maximal inhibitory concentration: > 20000 nM
Compound 4 ended at the assay's limit (the forecaster's own chance of this, stated with the estimate: 85%); the middle value does not contradict the limit.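

No step can be read from compound 2 to compound 4, as both values are limits of the assay: the limit of > 20000 nM in this assay, at which 4 of the 4 values shown sit.

The compounds shown leave open whether 4-methylphenyl to 4-methoxyphenyl changes activity on either core, and whether any member of the series gives a measurable value.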